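Cytotoxicity of chalcone amides on Vero cells: a methyl analogue

This account rests on a few compounds, and the source may have more. Where it says the series, first, only, none or still open, it means among the compounds named here.

The series shares a core carrying a methyl ester and an amide-linked chalcone, and differs only in the ring on the carbonyl carbon of that chalcone. Compound 1 `COC(=O)c1cc(-c2cccc(NC(=O)c3ccc(/C=C/C(=O)c4cccc(F)c4)cc3)c2)on1` carries a 3-fluorophenyl there. In an ADME assay on Vero cells (Chlorocebus sabaeus) for cytotoxicity, read by MTT assay, with a stated time of 72 h (a lower number here means that less compound is tolerated, a higher number that more compound is tolerated), compound 1 reaches only the limit of the assay, > 40 ug/mL. Compound 2 `COC(=O)c1cc(-c2cccc(NC(=O)c3ccc(/C=C/C(=O)c4ccc(Cl)cc4)cc3)c2)on1` carries a 4-chlorophenyl instead. In this assay compound 2 likewise reaches only a limit, > 50 ug/mL. The step that the two limits leave unreadable from compound 1 to compound 2 therefore cannot be sized, since the limit of > 40 ug/mL in this assay, at which 1 of the 2 values shown sits, and the limit of > 50 ug/mL in this assay, at which 1 of the 2 values shown sits, both stop short of a number. Within the data shown here, compound 2 thus stands at a limit, with the only other value shown also a limit.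

Compound 3 `COC(=O)c1cc(-c2cccc(NC(=O)c3ccc(/C=C/C(=O)c4ccccc4C)cc3)c2)on1` is the next variation: 2-methylphenyl in place of 4-chlorophenyl on a carbonyl carbon. Among the measured compounds shown here, no measured step resolves a number on either side of this change, so the only guide is that both measured compounds were tolerated up to their limits. Compound 3 is therefore expected to behave in the same way, with an estimated step that the limit leaves unreadable from compound 2 to compound 3 that amounts to none beyond the scatter. The estimate for compound 3 is 60 ug/mL, within a range from 30 ug/mL to 120 ug/mL.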

Compound 3, half-maximal cytotoxic concentration: > 25 ug/mL
Compound 3: only a limit was reported (the forecaster's own chance of this, stated with the estimate: 70%); the middle value is on the limit's open side.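

In this assay compound 3 reaches only a limit, > 25 ug/mL. The steps from compound 1 and from compound 2 to compound 3 cannot be read, as all three values are limits. The compounds shown leave open the half-maximal cytotoxic concentration of each compound, and whether the ring on the carbonyl carbon affects it at all.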